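Aryl swap on the piperazine nitrogen: compound 3 to compound 4

The source may hold more compounds than are shown below. What is called first, only, known or untested is meant among the compounds shown, and "the series" means these compounds.

Compound 3 `COc1ccccc1N1CCN(C(=O)CN2C(=O)CC(C)(c3ccccc3)C2=O)CC1` stands, in a functional assay on the whole organism (strain CD-1) with Mus musculus as the target, in the maximal electroshock model, with a stated time of 0.5 h (on this read-out lower numbers stand for an effect already at smaller amounts and higher numbers for an effect only at larger amounts of compound), at 100 mg/kg. That number is level with compound 1 `CC1(c2ccccc2)CC(=O)N(CC(=O)N2CCN(c3ccccc3F)CC2)C1=O`, which gives 100 mg/kg, and together they are the lowest of the three numbers; the difference is no change at the digits printed from compound 1 to compound 3 (within the scatter). Compound 2 `CC1(c2ccccc2)CC(=O)N(CC(=O)N2CCN(c3ccccc3)CC2)C1=O` is the furthest, with 300 mg/kg, so that a 3.0-fold lower number from compound 2 to compound 3 (0.48 log units; beyond the scatter).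

Compound 4 `CC1(c2ccccc2)CC(=O)N(CC(=O)N2CCN(c3ccc(Cl)c(Cl)c3)CC2)C1=O` differs from compound 3 in one place: 3,4-dichlorophenyl in place of 2-methoxyphenyl on an amine nitrogen in a ring. The group that leaves carries one hydrogen-bond acceptor, the group that enters carries none and brings two chlorines.

Among the measured compounds shown here, none of the measured steps covers this exact change. They show only what happens when a single substituent on that aromatic ring is exchanged: a 3.0-fold higher number from compound 1 to compound 2 (0.48 log units; beyond the scatter) and a 3.0-fold lower number from compound 2 to compound 3 (0.48 log units; beyond the scatter), both modest, and no change at the digits printed from compound 1 to compound 3 (within the scatter). The unsubstituted ring of compound 2 gives the highest number, the two substituted rings give the same lower number. The expectation for the step in this assay is therefore a small one, most likely no change beyond the scatter or a modest rise toward the number of compound 2: a 1.5-fold higher number from compound 3 to compound 4 (0.18 log units; within the scatter) is the estimated step. For compound 4 the estimated value is 150 mg/kg, with a range from 50 mg/kg to 450 mg/kg.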

Compound 4, minimum effective dose: "not active" (no number reported)
No number was reported for compound 4; no gap can be computed for the estimate.
By their numbers in this assay, from the lowest: compounds 1 and 3 (each within the scatter of the next); then compound 2.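

Among the compounds shown here, compound 4 is reported as not active in this assay, without a number, so no step from compound 3 to compound 4 can be read. The compounds shown leave open whether that result belongs to the 3,4-dichlorophenyl group as a whole or to a single chlorine. Nothing given here bears on the reason for the result.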